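Pyrrolidinyl to diethylamino swap in a diamide series

The compounds below may be only part of what the source reports. "The series", "measured", "known", "first", "only" and "open" are said of these compounds alone.

Values in a functional assay on MCF7 cells (Homo sapiens) for inhibition (a lower number here means a stronger inhibitor, a higher number a weaker inhibitor), for the three measured compounds:

Compound 1 `CCN(CC)CCNC(=O)CC(CC(=O)NC1Cc2ccccc2C1)c1ccc(Cl)cc1` gives 75000 nM.
Compound 2 `O=C(CC(CC(=O)NC1Cc2ccccc2C1)c1ccc(Cl)cc1)NCCN1CCCC1` gives only a limit of the assay, > 100000 nM.
Compound 3 `CN(C(=O)CC(CC(=O)NCCN1CCCC1)c1ccccc1)C1Cc2ccccc2C1` gives only a limit of the assay, > 100000 nM.

Compound 1 and compound 2 share a core and differ in one place: diethylamino in place of pyrrolidin-1-yl on a saturated chain carbon, two bonds along the chain from an amide-type nitrogen. The step between them is an at least 1.3-fold lower number from compound 2 to compound 1 (0.12 log units; that floor lies within the scatter); its size is known only as a floor because compound 2 sits at the limit of > 100000 nM in this assay, at which 2 of the 3 values shown sit.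

Compound 3 carries a different core; how the core of compound 3 differs from that of compound 2 is not broken down here. Compound 4 `CCN(CC)CCNC(=O)CC(CC(=O)N(C)C1Cc2ccccc2C1)c1ccccc1` has not yet been measured in this assay. It stands to compound 3 as compound 1 stands to compound 2: diethylamino in place of pyrrolidin-1-yl on a saturated chain carbon, two bonds along the chain from an amide-type nitrogen. The place of the change is the same in both pairs, so this is the same change made on a second core.

What can be expected for compound 4 rests on that single earlier pair. The step from compound 2 to compound 1 was small and bounded by the limit, and compound 3 itself sits at the same limit, (the limit of > 100000 nM in this assay, at which 2 of the 3 values shown sit). The step from compound 3 to compound 4 is therefore estimated at about an at least 1.1-fold lower number from compound 3 to compound 4 (0.04 log units; that floor lies within the scatter), within the scatter, with a real chance that only a limit is reported. Compound 4 is expected to give around 90000 nM in this assay, with a plausible range from 35000 nM to 300000 nM.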

Compound 4, half-maximal inhibitory concentration: > 100000 nM
Compound 4: only a limit was reported; the forecaster's own chance of this, stated with the estimate: 60%; middle value at least 1.1-fold (0.04 log units) from the limit.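

In this assay compound 4 gives only a limit of the assay, > 100000 nM. Compound 3 also stands at a limit, so no step between compound 3 and compound 4 can be read: the limit of > 100000 nM in this assay, at which 3 of the 4 values shown sit.

The compounds shown leave open how far compound 3 and compound 4 lie past that limit, and so whether diethylamino in place of pyrrolidin-1-yl shifts the number on this core at all.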